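A few compounds are considered here, and "the series" means these few. Any claim that something is new, unique, unknown or untested is made for them only; others in the source may bear on it.

Measured in a functional assay on the whole organism with Rattus norvegicus as the target; a higher number here means that more compound is needed for the effect, a lower number that less compound is needed:
- Compound 1 `CCOC(=O)C(=O)Nc1nc(-c2cccc(OC)c2)cs1`: about 20 mg/kg
- Compound 2 `CCOC(=O)C(=O)Nc1nc(-c2ccc([N+](=O)[O-])cc2)cs1`: > 100 mg/kg, a limit of the assay and not a number
- Compound 3 `CCOC(=O)C(=O)Nc1nc(-c2cc(OC)cc(OC)c2)cs1`: about 10 mg/kg

Among the measured compounds shown here, compound 3 cannot be separated from compound 1, the only other compound with a number: a 2.0-fold lower number from compound 1 to compound 3 (0.30 log units; within the scatter).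

Compound 4 `COc1cc(OC)cc(-c2csc(NC(=O)C(=O)O)n2)c1` has hydrogen in place of ethyl on an oxygen next to a carbonyl group, so ethoxycarbonyl becomes carboxy: hydrogen in place of ethyl on an oxygen next to a carbonyl group.

For the measured compounds named here, no measured step covers this change. Going by the values given here, the only step with a number, a 2.0-fold lower number from compound 1 to compound 3 (0.30 log units; within the scatter), is methoxy in place of hydrogen on an aromatic carbon, at a different place in the molecule. It therefore gives no direct guide to the size or direction of the new step, and the range has to stay wide.

The step expected in this assay is no change at the digits printed from compound 3 to compound 4 (within the scatter), with no change beyond the scatter anticipated in either direction.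

For compound 4 the estimated value is 10 mg/kg, with an expected range from 2 mg/kg to 50 mg/kg.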

Compound 4, dose for half-maximal effect: about 1 mg/kg
For compound 4 the middle estimate is 10-fold (1.00 log units) above the measured one; the whole stated range lies above it.
By their numbers in this assay, from the lowest: compound 4; then compounds 3 and 1 (each within the scatter of the next). At a limit, above all of these: compound 2.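

In this assay, the replacement of ethoxycarbonyl by carboxy gives a 10-fold lower number from compound 3 to compound 4 (1.00 log units; beyond the scatter) and shows that ethyl can leave this position without any rise in the dose needed. The only earlier numbered step, a 2.0-fold lower number from compound 1 to compound 3 (0.30 log units; within the scatter), lay on an aromatic carbon, so the position on an oxygen next to a carbonyl group is the first shown to move the number beyond the scatter. Nothing measured here accounts for the size of this step.

Going by these compounds, whether carboxy in place of ethoxycarbonyl gives a similar step on compound 1 remains open, as does the outcome with a longer chain or an amine on the same carbonyl. For compound 2, > 100 mg/kg is a limit of the assay and not a number, so the same change on compound 2 cannot be judged from it.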